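The compounds below may be only part of what the source reports. "The series", "measured", "known", "first", "only" and "open" are said of these compounds alone.

Compound 1 `COc1cc(C)c(Cl)cc1C1=NN(c2ccc(S(N)(=O)=O)cc2)C(c2ccccc2)C1`: 55.3% in a functional assay on the whole organism (strain Wistar) for inhibition, with Rattus norvegicus as the target, read by paw edema, with stated times of 30 min and 3 h, at a dose of 20 mg/kg by the oral route; on this read-out higher numbers stand for more inhibition at the one dose given (going by the name of the read-out) and lower numbers for less inhibition
Compound 2 `COc1cc(C)c(Cl)cc1C1=NN(c2ccc(S(N)(=O)=O)cc2)C(/C=C/c2ccccc2)C1`: 55.3% in this assay

Compound 2 stands level with compound 1 on these numbers, the step of no change at the digits printed from compound 1 to compound 2 (within the scatter) lying within the scatter. Compound 3 `COc1cc(C)c(Cl)cc1C1=NN(c2ccc(S(N)(=O)=O)cc2)C(c2ccc(N(C)C)cc2)C1` differs from compound 2 by 4-(dimethylamino)phenyl in place of 2-phenylethenyl on a saturated ring carbon. Within the data shown here, the one measured step at this saturated ring carbon, no change at the digits printed from compound 1 to compound 2 (within the scatter), was flat, and no measured step exchanges this group for one bearing a nitrogen, so the data give no direction. Compound 3 is therefore expected to move by a number 0.3 percentage points lower from compound 2 to compound 3 (within the scatter), a step that should stay within the scatter. Compound 3 is estimated at 55% in this assay, within a range of 42% to 68%.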

Compound 3, a percentage reported as inhibition, in the whole organism at one dose (the size of the read-out at that dose, not a potency): 78.9%
Beside the measured number, compound 3's estimate is 23.9 percentage points below it; the measured number lies above the stated range.
By their numbers in this assay, from the lowest: compounds 1 and 2 (each within the scatter of the next); then compound 3.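

The saturated ring carbon, flat in the earlier exchange, is not indifferent to its substituent: in this assay, 4-(dimethylamino)phenyl in place of 2-phenylethenyl gives a number 23.6 percentage points higher from compound 2 to compound 3 (beyond the scatter). Against the plain phenyl, dimethylamino in place of hydrogen on an aromatic carbon gives a number 23.6 percentage points higher from compound 1 to compound 3 (beyond the scatter), so this single added group separates the pair. No available evidence bears on the reason for this gain. As far as these compounds go, whether a primary amine or a methoxy group on that aromatic carbon would give a similar result remains open. So does whether the gain persists at other doses.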